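Cytotoxicity limits across two five-membered cores

This account rests on a few compounds, and the source may have more. Where it says the series, first, only, none or still open, it means among the compounds named here.

Compound 1 `COc1ccc(-c2ccc(CO[C@@H]3COc4nc([N+](=O)[O-])cn4C3)s2)cc1F` carries a 3-fluoro-4-methoxyphenyl group. In an ADME assay on Vero cells (Chlorocebus sabaeus) for cytotoxicity, with a stated time of 72 h (on this read-out lower numbers stand for stronger inhibition and higher numbers for weaker inhibition), compound 1 reaches only a limit, > 128000 nM. Compound 2 `COc1ccc(-c2ccc(CO[C@@H]3COc4nc([N+](=O)[O-])cn4C3)s2)cn1` differs by 6-methoxypyridin-3-yl in place of 3-fluoro-4-methoxyphenyl on an aromatic carbon. In this assay compound 2 likewise stops at a limit, > 128000 nM. The step that the two limits leave unreadable from compound 1 to compound 2 cannot be sized; what holds is the limit of > 128000 nM in this assay, at which 3 of the 3 values shown sit. Compound 3 `COc1ccc(-c2cc(CO[C@@H]3COc4nc([N+](=O)[O-])cn4C3)on2)cc1F` has a different core; the difference between the two cores is not broken down here. In this assay compound 3 also gives a limit, > 128000 nM. Compound 4 `COc1ccc(-c2cc(CO[C@@H]3COc4nc([N+](=O)[O-])cn4C3)on2)cn1`, not yet measured, differs from compound 3 by 6-methoxypyridin-3-yl in place of 3-fluoro-4-methoxyphenyl on an aromatic carbon; this is the same kind of change as from compound 1 to compound 2, though the place is now on a five-membered aromatic ring with 1 nitrogen and 1 oxygen, next to the ring nitrogen and two ring bonds from the ring oxygen, rather than on a five-membered aromatic ring with 1 sulfur, next to the ring sulfur. The step that the limit leaves unreadable from compound 3 to compound 4 is expected to remain unreadable because of the limit of > 128000 nM in this assay, at which 3 of the 3 values shown sit. Compound 4 is expected at 200000 nM, between 100000 nM and 500000 nM.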

Compound 4, half-maximal inhibitory concentration: > 128000 nM
Compound 4: a limit, no number; the forecaster's own chance of this, stated with the estimate: 85%; the middle value is on the limit's open side.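

In this assay the step from compound 3 to compound 4, like that from compound 1 to compound 2, cannot be read: the limit of > 128000 nM in this assay, at which 4 of the 4 values shown sit.

Left open is how large an effect 6-methoxypyridin-3-yl in place of 3-fluoro-4-methoxyphenyl has on either core, or whether it has any.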